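This account rests on a few compounds, and the source may have more. Where it says the series, first, only, none or still open, it means among the compounds named here.

Measured compounds and their values in a functional assay (Homo sapiens), tested at 10 uM; a higher number here means a weaker effect of the compound at the concentration tested, a lower number a stronger effect:
- compound 1, `O=C(/C=C/c1ccccc1)N1CCc2c(Cl)c(O)c(O)c(Cl)c2C1`: 41%
- compound 2, `N#Cc1ccc(CCCC(=O)N2CCc3c(Cl)c(O)c(O)c(Cl)c3C2)nc1`: 34%
- compound 3, `O=C(CCCc1ncc(C(F)(F)F)cc1Cl)N1CCc2c(Cl)c(O)c(O)c(Cl)c2C1`: 5%

All three compounds share the same core and differ only in the group carried on the amide side chain. Compound 1 shows the highest number of the three in this assay. The value of compound 2 lies within the usual scatter of that of compound 1, so the two cannot be told apart. Compound 3, by contrast, sits well below compound 1, beyond the scatter, and so shows the clearly stronger effect of the set.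

Compound 4, `O=C(/C=C/c1cccnc1)N1CCc2c(Cl)c(O)c(O)c(Cl)c2C1`, has not yet been measured. It differs from compound 1 in one place: pyridin-3-yl in place of phenyl on a double-bonded chain carbon bound to a double-bonded chain carbon. Among the measured compounds shown here, since no measured pair shows this exact change, the size of the step can only be guessed. The change is small in what it counts, and the expectation is that the step from compound 1 to compound 4 in this assay, a number 3 percentage points lower from compound 1 to compound 4 (within the scatter), stays within or close to the scatter. Compound 4 is therefore estimated at 38%, with a range from 20% to 60%.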

Compound 4, a percentage reported as activity, at one concentration (the size of the read-out at that concentration, not a potency): 44%
Beside the measured number, compound 4's estimate is 6 percentage points below it; the measured number falls inside the stated range.
By their numbers in this assay, from the lowest: compound 3; then compounds 2, 1 and 4 (each within the scatter of the next).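

In this assay, putting pyridin-3-yl in place of phenyl on a double-bonded chain carbon bound to a double-bonded chain carbon gives a number 3 percentage points higher from compound 1 to compound 4 (within the scatter). Among the compounds shown here, this is the first comparison in the set that isolates a single change, since the earlier compounds differ from one another in more than one place. At this position, then, swapping one ring carbon for a nitrogen, which adds one hydrogen-bond acceptor, produces no step that can be told apart from the scatter, and nothing measured here speaks to why.

On these data alone, it remains open whether pyridin-4-yl or thiophen-2-yl in the same place would also leave the read-out unmoved. Also open, as far as these compounds go, is what a carboxylic acid or an amine on the phenyl ring would do.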